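The source may hold more compounds than are shown below. What is called first, only, known or untested is meant among the compounds shown, and "the series" means these compounds.

Compound 1 `CC(C)[C@H](NC(=O)COc1cccc2ccccc12)C(=O)N[C@@H](CC(=O)O)C(=O)COc1nc2ccccc2[nH]1`: > 200000 nM in a functional assay on Jurkat cells (Homo sapiens) for inhibition; on this read-out lower numbers stand for stronger inhibition and higher numbers for weaker inhibition
Compound 2 `Cc1cc(C)nc(SCC(=O)[C@H](CC(=O)O)NC(=O)[C@@H](NC(=O)COc2cccc3ccccc23)C(C)C)n1`: > 200000 nM in this assay

In this assay compound 1 reaches only a limit, > 200000 nM. Compound 2 likewise reaches only a limit, > 200000 nM. The step that the two limits leave unreadable from compound 1 to compound 2 therefore cannot be read, since (the limit of > 200000 nM in this assay, at which 2 of the 2 values shown sit). Compound 3 `CC(C)[C@H](NC(=O)COc1cccc2ccccc12)C(=O)N[C@@H](CC(=O)O)C(=O)COc1cncc2ccccc12` differs from compound 2 by (isoquinolin-4-yl)oxy in place of (4,6-dimethylpyrimidin-2-yl)sulfanyl on a saturated chain carbon bound to a carbonyl carbon. For the measured compounds named here, the only measured step at this position, a step that the two limits leave unreadable from compound 1 to compound 2, gives no readable size, so no direction beyond the scatter can be drawn from it. Compound 3 is expected to show the step of a number no higher from compound 2 to compound 3 (the limit leaves the size open), most likely remaining at a limit. The estimate for compound 3 in this assay is 200000 nM, with a range from 50000 nM to 600000 nM.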

Compound 3, half-maximal inhibitory concentration: 166000 nM
Beside the measured number, compound 3's estimate is 1.2-fold (0.08 log units) above it; measured number inside the range.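

In this assay compound 3 is the only one of the three to give a number rather than a limit, so this position, on a saturated chain carbon bound to a carbonyl carbon, now yields readable steps: an at least 1.2-fold lower number from compound 2 to compound 3 (0.08 log units; that floor lies within the scatter) and, with the oxygen kept and isoquinolin-4-yl in place of 1H-benzimidazol-2-yl, an at least 1.2-fold lower number from compound 1 to compound 3 (0.08 log units; that floor lies within the scatter). Going by these compounds, both are floors only, and their full size stays open because of the limit: the limit of > 200000 nM in this assay, at which 2 of the 3 values shown sit. On these data alone, whether an amine, a carboxylic acid or a longer chain at this position would give a clearly lower number remains open.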